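Bromo for Methoxy: A Repeated Change Against Cell Growth

The source may hold more compounds than are shown below. What is called first, only, known or untested is meant among the compounds shown, and "the series" means these compounds.

Of the compounds shown here, three have been tested in a functional assay on A549 cells (Homo sapiens) for antiproliferative activity, read by MTT assay; a higher number here means a weaker inhibitor, a lower number a stronger inhibitor. Compound 1 `COc1ccc(-c2ccnc(Nc3ccc(Cl)cc3Cl)n2)cc1` gives 7330 nM, compound 2 `Clc1ccc(Nc2nccc(-c3ccc(Br)cc3)n2)c(Cl)c1` gives 3780 nM, and compound 3 `COc1ccc(-c2ccnc(Nc3cccc(OC)c3)n2)cc1` gives 6530 nM. Compound 2 differs from compound 1 in one place, (bromo in place of methoxy on an aromatic carbon), and that change gave a 1.9-fold lower number from compound 1 to compound 2 (0.29 log units; within the scatter). Compound 4 `COc1cccc(Nc2nccc(-c3ccc(Br)cc3)n2)c1` is not yet measured; it differs from compound 3 by bromo in place of methoxy on an aromatic carbon, the same change at the same kind of place. The difference between the core of compound 1 and the core of compound 3 is not broken down here, and their values lie within the scatter of each other. Because the earlier change gave a 1.9-fold lower number from compound 1 to compound 2 (0.29 log units; within the scatter), a step of similar size, a 1.9-fold lower number from compound 3 to compound 4 (0.28 log units; within the scatter), is expected in this assay. Compound 4 is therefore estimated at 3400 nM, most likely between 1500 nM and 8000 nM.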

Compound 4, half-maximal inhibitory concentration: 82700 nM
Beside the measured number, compound 4's estimate is 24-fold (1.39 log units) below it, and the stated range ends below it.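

In this assay, bromo in place of methoxy on an aromatic carbon gave a 13-fold higher number from compound 3 to compound 4 (1.10 log units; beyond the scatter), a clearly weaker result on this core. Set side by side, the two steps do not agree, so the step seen on the first core did not carry over to the second: the same change on two cores in this assay, a 1.9-fold lower number (0.29 log units; within the scatter) from compound 1 to compound 2 and a 13-fold higher number (1.10 log units; beyond the scatter) from compound 3 to compound 4, 25-fold (1.39 log units) apart, beyond the scatter of two such steps. This shows that, in these two pairs, the result of the change depends on the rest of the molecule, but it does not show which difference between the cores is responsible or what the change would do on any other core.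

The compounds shown leave open whether the weakening on the core of compound 3 is specific to bromo, or whether an amine or a carboxylic acid in that place would behave differently. They also leave open whether the chloro groups of compound 1 or the second methoxy of compound 3 decide how the change turns out.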